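A few compounds are considered here, and "the series" means these few. Any claim that something is new, unique, unknown or untested is made for them only; others in the source may bear on it.

In a functional assay on MCF7 cells (Homo sapiens) for antiproliferative activity, read by MTT assay (on this read-out lower numbers stand for stronger inhibition and higher numbers for weaker inhibition), compound 1 `Cc1c(-n2cc(COc3ccc(/C=C/C(=O)c4cc5c(cc4O)OC(C)(C)CC5)cc3)nn2)cccc1[N+](=O)[O-]` gives 176000 nM and compound 2 `CC(=O)c1ccc(-n2cc(COc3ccc(/C=C/C(=O)c4ccc5c(c4O)CCC(C)(C)O5)cc3)nn2)cc1` gives 171000 nM. These two numbers lie within the usual scatter of each other, so compound 1 cannot be separated from compound 2. Compound 3 `Cc1ccc(-n2cc(COc3ccc(/C=C/C(=O)c4ccc5c(c4O)CCC(C)(C)O5)cc3)nn2)cc1Br` has no number and is reported as "not active" (no number reported). Compound 4 `CCCCCn1cc(COc2ccc(/C=C/C(=O)c3cc4c(cc3O)OC(C)(C)CC4)cc2)nn1` keeps the core of compound 1 and carries one change: pentyl in place of 2-methyl-3-nitrophenyl on an aromatic nitrogen. Going by the values given here, no measured pair shows what such a swap does, so no step beyond the scatter is expected in this assay. The estimated change is a 1.4-fold lower number from compound 1 to compound 4 (0.13 log units; within the scatter). For compound 4 the estimated value is 130000 nM, with an expected range of 45000 nM to 350000 nM.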

Compound 4, half-maximal inhibitory concentration: "not active" (no number reported)
Compound 4: no number reported, and the estimate cannot be compared.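

Going by these compounds alone, compound 4 is reported as "not active" without a number, so no step from compound 1 to compound 4 can be read in this assay, and no evidence bears on this result. Going by these compounds, how pentyl in place of 2-methyl-3-nitrophenyl shifts the number stays open.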